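The source may hold more compounds than are shown below. What is called first, only, known or untested is meant among the compounds shown, and "the series" means these compounds.

Compound 1 `N#Cc1c(-c2ccc(Cl)cc2)cc(-c2ccc(Cl)cc2)n(C(=O)c2ccccc2)c1=O`: 3.75 ug/mL in a functional assay on HepG2 cells (Homo sapiens) for cytotoxicity, read by sulforhodamine B assay, with a stated time of 48 h; on this read-out lower numbers stand for stronger inhibition and higher numbers for weaker inhibition.
Compound 2 `N#CCn1c(-c2ccc(Cl)cc2)cc(-c2ccc(Cl)cc2)c(C#N)c1=O`: "not active" (no number reported) in this assay.

In this assay compound 1 gives 3.75 ug/mL, whereas compound 2 is reported only as "not active" (no number reported), so no single number places compound 2 on this scale. Compound 3 `N#Cc1c(-c2ccc(Cl)cc2)cc(-c2ccc(Cl)cc2)[nH]c1=O` differs from compound 2 by hydrogen in place of cyanomethyl on an aromatic nitrogen. For the measured compounds named here, no measured pair shows this change, so its size and direction in this assay cannot be read from the data. Because compound 2 gives "not active" (no number reported), weak inhibition remains plausible for compound 3. Compound 3 is expected to give 15 ug/mL (3 ug/mL to 60 ug/mL) in this assay.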

Compound 3, half-maximal inhibitory concentration: "not active" (no number reported)
Compound 3: no number reported; there is nothing to compare the estimate with.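

Compound 2 and compound 3 are both reported only as "not active" in this assay, so no step can be read between them. How much the cyanomethyl group on the aromatic nitrogen changes inhibition stays open, and nothing shown explains this result.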